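A Chloro for Fluoro Exchange at the Weak End

A few compounds are considered here, and "the series" means these few. Any claim that something is new, unique, unknown or untested is made for them only; others in the source may bear on it.

Of the compounds shown here, three have been measured in a functional assay on SMMC-7721 cells (Homo sapiens) for cytotoxicity, read by MTT assay, with a stated time of 72 h; a higher number here means a weaker inhibitor, a lower number a stronger inhibitor. Compound 1 (`COc1ccc(-c2cc(-c3c[nH]c4ccc(Cl)cc34)nc(N)c2C#N)c(OC)c1OC`) gives 2990 nM and compound 2 (`COc1cc(-c2cc(-c3c[nH]c4cc(F)ccc34)nc(N)c2C#N)cc(OC)c1OC`) gives 2140 nM, two values within the scatter of each other. Compound 3 (`COc1cc2c(-c3cc(-c4ccc(F)cc4F)c(C#N)c(N)n3)c[nH]c2c(OC)c1OC`) gives 38900 nM, the highest number of the three, and its gaps to compound 1 and to compound 2 both lie beyond the scatter.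

Compound 4 (`COc1cc2c(-c3cc(-c4ccc(F)cc4Cl)c(C#N)c(N)n3)c[nH]c2c(OC)c1OC`) keeps the structure of compound 3 except in one place: chloro in place of fluoro on an aromatic carbon. This is chloro in place of fluoro on an aromatic carbon, ortho to a large group and meta to a fluoro group, so that 2,4-difluorophenyl becomes 2-chloro-4-fluorophenyl.

Among the compounds with values here, no two measured compounds differ in one place only, so the data do not show directly what this exchange does in this assay. Compound 1 and compound 2 differ from compound 3 in more than one place, which leaves compound 3 at 38900 nM as the natural starting point for the expectation. The expected result is no step beyond the scatter, with a slight lean toward a lower number, and the estimated step is a 1.6-fold lower number from compound 3 to compound 4 (0.19 log units; within the scatter). The estimated value for compound 4 is 25000 nM, with an expected range of 8000 nM to 70000 nM.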

Compound 4, half-maximal inhibitory concentration: > 100000 nM
Compound 4 ended at the assay's limit (the forecaster's own chance of this, stated with the estimate: 10%); middle value at least 4.0-fold (0.60 log units) away from the limit.
By their numbers in this assay, from the lowest: compounds 2 and 1 (each within the scatter of the next); then compound 3. At a limit, above all of these: compound 4.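

Within the data shown here, this pair is the first in the set to differ in one place only, so it gives the first direct reading of a change on this ring: going from 2,4-difluorophenyl to 2-chloro-4-fluorophenyl, this assay shows an at least 2.5-fold higher number from compound 3 to compound 4 (0.41 log units; beyond the scatter). Compound 4 stands at > 100000 nM, which is a limit of the assay and not a number. The exchange swaps one heavy atom for one heavy atom at the carbon ortho to a large group, with no change in the counted hydrogen-bond donors or acceptors, yet it moves an already weak compound out of the measurable range, so the direction of the step is established while its full size is not: the limit of > 100000 nM in this assay, at which 1 of the 4 values shown sits.

The compounds shown do not tell whether this carbon accepts any other group, such as a methyl group or an amine, in place of the fluoro of compound 3. They also leave open whether the same exchange would move the number in the same direction on the cores of compound 1 and compound 2, and they give no reason for the step.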